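Swapping the carbamoyl arm for a benzoyl arm

A few compounds are considered here, and "the series" means these few. Any claim that something is new, unique, unknown or untested is made for them only; others in the source may bear on it.

Compound 1, `O=C(Nc1cccc(-n2cc(-c3ccncc3)c(-c3cc(O)cc(Cl)c3)n2)c1)Nc1ccc(Cl)c(C(F)(F)F)c1`, in a functional assay on NCI-H23 cells (Homo sapiens) for inhibition, read by sulforhodamine B assay, with a stated time of 48 h, tested at 0.01 uM (on this read-out higher numbers stand for a weaker effect at the one concentration tested and lower numbers for a stronger effect), gives 92%.
Compound 2, `O=C(Nc1cccc(-n2cc(-c3ccncc3)c(-c3cc(O)cc(Cl)c3)n2)c1)Nc1ccc(Cl)c(Cl)c1`, in this assay gives 96%.
Compound 3, `COc1cc(Cl)cc(-c2nn(-c3cccc(NC(=O)Nc4ccc(Cl)c(Cl)c4)c3)cc2-c2ccncc2)c1`, in this assay gives 93%.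

All three numbers sit close together, and each says that the compound barely slows the cells at the single concentration tested. Compound 3 stands second highest of the three, with compound 1 nearest and compound 2 furthest, but both gaps lie within the scatter, so no order among them can be read.

Compound 4, `COc1cc(Cl)cc(-c2nn(-c3cccc(NC(=O)c4cccc(C(F)(F)F)c4)c3)cc2-c2ccncc2)c1`, differs from compound 3 in one place: 3-(trifluoromethyl)phenyl in place of (3,4-dichlorophenyl)amino on a carbonyl carbon. This removes the single hydrogen-bond donor of that arm.

The two measured steps, a number 4 percentage points higher from compound 1 to compound 2 (within the scatter) and a number 3 percentage points lower from compound 2 to compound 3 (within the scatter), both changed a group at a far end of the molecule and both stayed within the scatter. Neither touches the carbonyl carbon altered here, so they give no direct guide. With every measured compound showing almost no effect, the expectation for compound 4 is a number in the same region, and the step of no change at the digits printed from compound 3 to compound 4 (within the scatter) is expected to stay within the scatter. Compound 4 is therefore estimated at 93%, in a range from 80% to 103%.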

Compound 4, a percentage reported as activity, at one concentration (the size of the read-out at that concentration, not a potency): 93%
Compound 4: the middle estimate sits on the measured number at the digits printed; the range from low to high includes it.
By their numbers in this assay, from the lowest: compounds 1, 3, 4 and 2 (each within the scatter of the next).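

In this assay, among the compounds shown here, the step of no change at the digits printed from compound 3 to compound 4 (within the scatter) is the first to alter the carbonyl carbon itself: 3-(trifluoromethyl)phenyl replaces (3,4-dichlorophenyl)amino, so the hydrogen-bond donor of the leaving group is gone and the read-out stays within the scatter. The earlier steps shown here changed other places and could say nothing about this one, so the result adds a new position to the set of changes that leave the number unmoved, but every compound here shows very little effect at the single concentration tested, and a flat result of this kind cannot show whether that donor matters at higher concentrations. Nothing available here accounts for the result or tells what the donor does in these cells.

As far as these compounds go, it remains open whether any group on this carbonyl carbon can bring the number clearly lower, for example a piperazine amine or a phenyl ring bearing a carboxylic acid. The compounds shown also leave open whether compound 3 and compound 4 would separate at other concentrations.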